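The source may report more compounds than this note shows. Statements on the series, on what has been measured and on what is new or still open speak of the compounds shown alone.

Of the compounds shown here, two have so far been measured in a functional assay on EL4 cells (Mus musculus) for inhibition, tested at 100 uM; a higher number here means more inhibition at the concentration tested (going by the name of the read-out), a lower number less inhibition. Compound 1 `OC[C@H]1OC(n2cnc3c(Nc4ccccc4)nccc32)[C@H](O)[C@@H]1O` gives 10% in this assay, and compound 2 `OC[C@H]1O[C@@H](n2cnc3c(SCc4ccccc4)nccc32)C[C@@H]1O` gives 11%. Compound 1 holds the lowest of the two numbers, but the nearest, compound 2, lies within the scatter of it, so the two read-outs cannot be told apart; both are small. Going by the values given here, no measured pair differs in a single place, so the data give no step size for any structural change.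

Compound 3 `CNc1nccc2c1ncn2C1O[C@H](CO)[C@@H](O)[C@H]1O` has not yet been measured in this assay. It differs from compound 1 in one place: methyl in place of phenyl on a nitrogen on an aromatic ring. Cut one bond further out, the change reads anilino to methylamino, with a group of one heavy atom and no ring taking the place of a six-membered aromatic ring of carbon.

Among the compounds with values here, because compound 1 gives 10% and no measured step shows what such a change does, compound 3 is expected to show a step of no change at the digits printed from compound 1 to compound 3 (within the scatter) of no size beyond the scatter. The estimate for compound 3 in this assay is 10%, with a range from 0% to 25%.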

Compound 3, a percentage reported as inhibition, at one concentration (the size of the read-out at that concentration, not a potency): 11%
The estimate for compound 3 lay 1 percentage points below the measured number; measured number inside the range.
By their numbers in this assay, from the lowest: compounds 1, 2 and 3 (each within the scatter of the next).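

Methyl in place of phenyl on a nitrogen on an aromatic ring gives a number 1 percentage points higher from compound 1 to compound 3 (within the scatter) in this assay, and this is the first step in the series that can be read for a single structural change. It shows that anilino and methylamino cannot be told apart at this position in this read-out: the six-membered aromatic ring of carbon can be exchanged for a group of one heavy atom and no ring without a difference beyond the scatter, with compound 1 at 10% and compound 3 at 11%, both small numbers. No measurement here offers any explanation for this result.

The compounds shown leave open whether any substituent on this nitrogen, such as a longer chain, a primary amine or a carboxylic acid, would move the read-out beyond the scatter. Going by these compounds alone, they also leave open whether this lack of difference would hold on a core carrying other changes, since compound 2 differs from compound 1 and compound 3 in more than one place and gives no step.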